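The source may hold more compounds than are shown below. What is called first, only, known or untested is meant among the compounds shown, and "the series" means these compounds.

Compound 1 `N#Cc1ccc(NC(=O)c2ccc(F)cc2O)cc1`: 1380 nM in a functional assay on HL-60 cells (Homo sapiens) for cytotoxicity, read by luminescence and CellTiter-Glo, with a stated time of 3 days; a higher number here means a weaker inhibitor, a lower number a stronger inhibitor
Compound 2 `N#Cc1ccc(NC(=O)c2cc(-c3cccnc3)ccc2O)cc1`: 7960 nM in this assay
Compound 3 `Cc1cccc(C(=O)Nc2ccc(C#N)cc2)c1O`: its result in this assay is > 10000 nM, a limit of the assay rather than a number the limit of > 10000 nM in this assay, at which 1 of the 3 values shown sits.

Of the two numbers, compound 2 stands highest. Compound 1 gives the nearest value, and the gap between them lies beyond the usual scatter. Compound 4 `N#Cc1ccc(NC(=O)c2cc(-c3ccccc3)ccc2O)cc1` is not yet measured and differs from compound 2 in one place: phenyl in place of pyridin-3-yl on an aromatic carbon. Going by the values given here, no measured pair shows this change, so the direction is uncertain; the step in this assay is expected to be small, probably within the scatter, with at most a modest move towards a lower number. Compound 4 is therefore estimated at 5000 nM, with a range from 1500 nM to 15000 nM. That estimate means a step of a 1.6-fold lower number from compound 2 to compound 4 (0.20 log units; within the scatter).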

Compound 4, half-maximal inhibitory concentration: 1350 nM
Compound 4: middle estimate off by 3.7-fold (0.57 log units), on the high side, outside the stated range (below it).
By their numbers in this assay, from the lowest: compounds 4 and 1 (each within the scatter of the next); then compound 2. At a limit, above all of these: compound 3.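

On this aromatic carbon, para to a hydroxy group, the choice of ring matters: phenyl in place of pyridin-3-yl gives a 5.9-fold lower number from compound 2 to compound 4 (0.77 log units; beyond the scatter) in this assay. The two rings have the same number of heavy atoms, so this single pair ties the change to the replacement of one ring nitrogen by carbon. Nothing at hand explains the step. Still open, from the compounds shown here alone, is how a carboxylic acid or an amine on the phenyl ring would read in this assay, and whether the step would hold on other cells.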